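Swapping a pyridyl for a fluorophenyl on the triazole

The compounds below may be only part of what the source reports. "The series", "measured", "known", "first", "only" and "open" are said of these compounds alone.

Compound 1 `C=C1C[C@]23C[C@@]1(O)CC[C@H]2c1ccc(O)c(C)c1[C@@H]3Cn1cc(-c2ccccn2)nn1` is the starting point. In a functional assay on SMMC-7721 cells (Homo sapiens) for cytotoxicity, read by MTT assay, with a stated time of 4 days (on this read-out lower numbers stand for stronger inhibition and higher numbers for weaker inhibition), compound 1 gives > 20000 nM, which is a limit of the assay rather than a measured number. Compound 2 `C=C1C[C@]23C[C@@]1(O)CC[C@H]2c1cc(Br)c(O)c(C)c1[C@@H]3Cn1cc(-c2ccccn2)nn1` carries a bromo in place of hydrogen on an aromatic carbon and in this assay gives > 20000 nM, again a limit. Within the data shown here, the step that the two limits leave unreadable from compound 1 to compound 2 therefore cannot be read, and the only evidence is the limit of > 20000 nM in this assay, at which 2 of the 2 values shown sit. Compound 3 `C=C1C[C@]23C[C@@]1(O)CC[C@H]2c1ccc(O)c(C)c1[C@@H]3Cn1cc(-c2ccc(F)cc2)nn1` differs from compound 1 by 4-fluorophenyl in place of pyridin-2-yl on an aromatic carbon. With no readable step to guide it, compound 3 is expected at 20000 nM, within a range from 6000 nM to 60000 nM. The expected step is a number no higher from compound 1 to compound 3 (the limit leaves the size open), most likely ending once more at the limit.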

Compound 3, half-maximal inhibitory concentration: > 20000 nM
Compound 3 was reported as a limit (the forecaster's own chance of this, stated with the estimate: 75%); the middle value sits exactly at the limit.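

Compound 1 and compound 3 are both reported only as limits, so no step between them can be read: the limit of > 20000 nM in this assay, at which 3 of the 3 values shown sit.

As far as these compounds go, whether 4-fluorophenyl in place of pyridin-2-yl changes anything in this assay stays open, as does what change to the shared core would give a measurable value.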